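The compounds below may be only part of what the source reports. "The series", "measured", "known", "first", "only" and "open" are said of these compounds alone.

Compound 1 `COc1ccc([C@@H]2C/C(=N\NC(=O)c3ccc(N)cc3)c3c(O)cc(OC)cc3O2)cc1` gives 3900 nM
Compound 2 `COc1ccc([C@@H]2C/C(=N\NC(=O)Cc3c[nH]c4ccccc34)c3c(O)cc(OC)cc3O2)cc1` gives 8600 nM

In a functional assay on L5178Y cells (Mus musculus) for inhibition, read by MTT assay, with a stated time of 24 h (on this read-out higher numbers stand for weaker inhibition and lower numbers for stronger inhibition), compound 2 stands highest of the two measured compounds. Compound 3 `COc1ccc([C@@H]2C/C(=N\NC(=O)OCc3ccccc3)c3c(O)cc(OC)cc3O2)cc1` differs from it by benzyloxy in place of (1H-indol-3-yl)methyl on a carbonyl carbon in one place, with benzyloxy in place of (1H-indol-3-yl)methyl on a carbonyl carbon. Within the data shown here, the only measured step at this carbonyl carbon is a 2.2-fold higher number from compound 1 to compound 2 (0.34 log units; beyond the scatter) and it is modest. A step of similar modest size is therefore expected in this assay leaning towards a lower number, although one step cannot settle the direction. The estimated change is a 1.4-fold lower number from compound 2 to compound 3 (0.16 log units; within the scatter) for this swap. For compound 3 the estimated value is 6000 nM with an expected range from 2500 nM to 14000 nM in this read-out.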

Compound 3, half-maximal inhibitory concentration: > 100000 nM
Compound 3 was reported as a limit (the forecaster's own chance of this, stated with the estimate: 3%); middle value at least 16-fold (1.22 log units) away from the limit.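

In this assay compound 3 is reported only as a limit, not as a number: the limit of > 100000 nM in this assay, at which 1 of the 3 values shown sits. Even so, this carbonyl carbon tolerates less than the earlier pair showed: benzyloxy gives an at least 11-fold higher number from compound 2 to compound 3 (1.06 log units; beyond the scatter) and an at least 25-fold higher number from compound 1 to compound 3 (1.40 log units; beyond the scatter), both large, whereas the earlier swap gave only a 2.2-fold higher number from compound 1 to compound 2 (0.34 log units; beyond the scatter). Among these three compounds, benzyloxy is the one group whose change at this place is large.

The compounds shown leave open whether the oxygen of benzyloxy or its phenyl ring accounts for this step. A plain benzyl or a methoxy group on the same carbonyl carbon would separate the two.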